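A few compounds are considered here, and "the series" means these few. Any claim that something is new, unique, unknown or untested is made for them only; others in the source may bear on it.

Notes on the series. Compound 1 `O=C(Nc1cc(C(F)(F)F)cc(C(F)(F)F)c1)c1ccc(Sc2ccc(O)cc2)cc1` and compound 2 `O=C(Nc1ccc(S(F)(F)(F)(F)F)cc1)c1ccc(Sc2ccc(O)cc2)cc1` share one core and differ only in the anilide substituent. In a functional assay on CWR22R cells (Homo sapiens) for antiproliferative activity, read by fluorescence and propidium iodide staining, with a stated time of 96 h (on this read-out lower numbers stand for stronger inhibition and higher numbers for weaker inhibition), compound 1 gives 3350 nM, and compound 2 gives 3710 nM; the two numbers lie within the scatter of each other, so neither stands apart. Compound 3 `O=C(Nc1cccc(C(F)(F)F)c1)c1ccc(Sc2ccc(O)cc2)cc1` is not yet measured. It differs from compound 1 in one place: hydrogen in place of trifluoromethyl on an aromatic carbon. Within the data shown here, no measured pair shows this change, so its size is open; the step from compound 1 to compound 3 is expected to be a 2.1-fold higher number from compound 1 to compound 3 (0.32 log units; beyond the scatter), toward a weaker number. For compound 3 the estimate in this assay is 7000 nM, within 3000 nM to 18000 nM.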

Compound 3, half-maximal inhibitory concentration: 5730 nM
Compound 3: the middle estimate sits 1.2-fold (0.09 log units) above what was measured; low and high end bracket the measured number.
By their numbers in this assay, from the lowest: compounds 1, 2 and 3 (each within the scatter of the next).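

Hydrogen in place of trifluoromethyl on an aromatic carbon gives a 1.7-fold higher number from compound 1 to compound 3 (0.23 log units; within the scatter) in this assay and is the only step in the series that can be read directly. At this position, then, the change is not resolved from the scatter, and the read-out does not depend measurably on this trifluoromethyl group. Nothing at hand accounts for the size of the step.

Open, from the compounds shown here alone, is whether an amine or a carboxylic acid at this position would give a step beyond the scatter. Also open, going by these compounds, is what replacing the remaining trifluoromethyl group with hydrogen would do.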